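The source may report more compounds than this note shows. Statements on the series, on what has been measured and on what is new or still open speak of the compounds shown alone.

Compound 1 `O=[N+]([O-])c1cccc(CSc2nnc(-c3ccc4c(c3)OCCO4)n2-c2ccccc2)c1` gives 7590 nM
Compound 2 `COc1cccc(CSc2nnc(-c3ccc4c(c3)OCCO4)n2-c2ccccc2)c1` gives 10100 nM

Both numbers come from a functional assay on SW 1116 cells (Homo sapiens) for antiproliferative activity, read by MTT assay, with a stated time of 24 h; on this read-out higher numbers stand for weaker inhibition and lower numbers for stronger inhibition. On these numbers compound 2 cannot be told apart from compound 1, and the two are the only measured points so far.

The next compound is compound 3 `Brc1ccccc1CSc1nnc(-c2ccc3c(c2)OCCO3)n1-c1ccccc1`, which has not yet been measured. Its difference from compound 2 is 2-bromophenyl in place of 3-methoxyphenyl on a saturated chain carbon bound to a sulfur. The exchange sits on a saturated chain carbon bound to a sulfur, and the rest of the molecule stays the same.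

Going by the values given here, only one measured step can serve as a guide, and it is a 1.3-fold higher number from compound 1 to compound 2 (0.12 log units; within the scatter). Among the compounds with values here, that step put methoxy in place of nitro on an aromatic carbon, which is a different exchange, and no compound carrying bromine has been measured. It is therefore weak evidence, but it gives no reason to expect a large shift. No step beyond the scatter is expected in this assay, and no direction can be favoured.

The expected step is a 1.1-fold lower number from compound 2 to compound 3 (0.05 log units; within the scatter). For compound 3 the estimate is 9000 nM, with an expected range from 3500 nM to 23000 nM.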

Compound 3, half-maximal inhibitory concentration: 7350 nM
Compound 3: the middle estimate sits 1.2-fold (0.09 log units) above what was measured; the range from low to high includes it.
By their numbers in this assay, from the lowest: compounds 3, 1 and 2 (each within the scatter of the next).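

In this assay, putting 2-bromophenyl in place of 3-methoxyphenyl on a saturated chain carbon bound to a sulfur gives a 1.4-fold lower number from compound 2 to compound 3 (0.14 log units; within the scatter) and putting it in place of 3-nitrophenyl gives a 1.0-fold lower number from compound 1 to compound 3 (0.01 log units; within the scatter) so the three compounds cannot be told apart. Going by these compounds alone, the earlier pair changed only the group on the aromatic ring, whereas the names 3-methoxyphenyl and 2-bromophenyl show that the group and its number on the ring both change here, and bromine enters for the first time, yet the reading still stays within the scatter. No measurement is available that would explain this sameness.

On these data alone, all three compounds keep a substituted phenyl ring on this chain carbon, so it remains open whether an amine, a carboxylic acid or a longer chain at the same place would move the number beyond the scatter. Also open, as far as these compounds go, is how the unsubstituted phenyl or 3-bromophenyl would read, which would separate the effect of bromine from that of its place on the ring.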